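A few compounds are considered here, and "the series" means these few. Any claim that something is new, unique, unknown or untested is made for them only; others in the source may bear on it.

Of the compounds shown here, three have so far been tested in a physicochemical assay for solubility, measured as kinetic solubility, with a stated time of 1 h, at pH 7.4; on this read-out higher numbers stand for higher solubility and lower numbers for lower solubility. Compound 1 (`CC(=O)Nc1nc(-c2cccc(O)c2)cs1`) gives 103000 nM. Compound 2 (`N#CCC(=O)Nc1nsc(-c2ccc(Cl)c(Cl)c2)n1`) gives 69000 nM, and these two numbers lie within the usual scatter of each other. Compound 3 (`O=C1CCCC(C(=O)NC2=NN(c3ccc(Cl)c(Cl)c3)CC2)N1`) gives 416000 nM, the highest of the three numbers, and its gap to each of the other two lies beyond the scatter.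

Compound 4 (`O=C(NC1=NN(c2ccc(Cl)c(Cl)c2)CC1)c1cccnc1F`) has not yet been measured. It differs from compound 3 in one place, with 2-fluoropyridin-3-yl in place of 6-oxopiperidin-2-yl on a carbonyl carbon. A six-membered non-aromatic ring therefore gives way to a six-membered aromatic ring.

Among the measured compounds shown here, no two tested compounds differ in only one place, so no measured step can serve as a guide, and the expectation is a judgement from the spread of values alone. Compound 3 sits at the top of that spread with 416000 nM, while compound 1 reads 103000 nM, so a new group on the carbonyl carbon seems more likely to land nearer the lower numbers. The expected change is an 8.3-fold lower number from compound 3 to compound 4 (0.92 log units; beyond the scatter), a fall beyond the scatter. For compound 4 the estimated value is 50000 nM, with an expected range from 10000 nM to 200000 nM.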

Compound 4, solubility: 13000 nM
Estimate against measurement, compound 4: 3.8-fold (0.59 log units) above; measured number inside the range.
By their numbers in this assay, from the lowest: compound 4; then compounds 2 and 1 (each within the scatter of the next); then compound 3.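

In this assay, the group on the carbonyl carbon proves able to move the number a long way: putting 2-fluoropyridin-3-yl in place of 6-oxopiperidin-2-yl gives a 32-fold lower number from compound 3 to compound 4 (1.51 log units; beyond the scatter) and takes the series from its highest number to its lowest. The heavy-atom count stays the same in this swap, so the step comes with a change in the kind of group and not in its count of heavy atoms: a non-aromatic ring with a hydrogen-bond donor leaves, and an aromatic ring with a fluorine and no hydrogen-bond donor enters. These differences arrive together in a single step, and no measurement available here says which of them accounts for the fall.

Still open, on these data alone, is how a plain phenyl ring or a pyridin-3-yl without its fluorine would read on this carbonyl carbon, which would help separate the role of the fluorine from that of the aromatic ring. Also open, as far as these compounds go, is whether a piperidin-2-yl without its ring carbonyl, or an open-chain amine, would stay near compound 3 at 416000 nM or fall toward compound 4 at 13000 nM in this assay.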